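Sulfamoyl to nitro: from compound 2 to compound 4

The compounds below may be only part of what the source reports. "The series", "measured", "known", "first", "only" and "open" are said of these compounds alone.

Measured in a toxicity assay on Huh-7.5 cells (Homo sapiens) for inhibition, read by MTT assay, with a stated time of 96 h; on this read-out lower numbers stand for higher toxicity in this test and higher numbers for lower toxicity in this test:
compound 1 `CCC(=O)Nc1cc(C(=O)Nc2ccc(N(C)C)cc2)ccc1OC(C)C`: 80600 nM
compound 2 `CN1CCN(Cc2ccc(NC(=O)c3ccc(OCCCCl)c(S(N)(=O)=O)c3)cc2C(F)(F)F)CC1`: 5470 nM
compound 3 `CC(C)Oc1ccc(C(=O)Nc2ccc(N(C)C)cc2)cc1N`: 72100 nM

Compound 2 stands lowest of the three numbers, apart from compound 1 and compound 3 by gaps beyond the scatter; compound 1 and compound 3 lie within the scatter of each other. For the measured compounds named here, the only step between measured compounds, a 1.1-fold lower number from compound 1 to compound 3 (0.05 log units; within the scatter), concerns a different core and a different group, so it says nothing about the exchange at hand. Compound 4 `CN1CCN(Cc2ccc(NC(=O)c3ccc(OCCCCl)c([N+](=O)[O-])c3)cc2C(F)(F)F)CC1` differs from compound 2 in one place: nitro in place of sulfamoyl on an aromatic carbon. Going by the values given here, no measured step covers this exchange, so no direction can be drawn from the data. The expected step of a 1.0-fold higher number from compound 2 to compound 4 (0.00 log units; within the scatter) is therefore none beyond the scatter. Compound 4 is estimated at 5500 nM, with a range from 2000 nM to 15000 nM.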

Compound 4, half-maximal cytotoxic concentration: 6800 nM
The estimate for compound 4 lay 1.2-fold (0.09 log units) below the measured number, and the stated range covers the measured number.
By their numbers in this assay, from the lowest: compounds 2 and 4 (each within the scatter of the next); then compounds 3 and 1 (each within the scatter of the next).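

In this assay, nitro in place of sulfamoyl on the aromatic carbon ortho to a 3-chloropropoxy group gives a 1.2-fold higher number from compound 2 to compound 4 (0.09 log units; within the scatter) and is the only step shown at this position. Both groups are tolerated here without a change beyond the scatter, although nitro lacks the hydrogen-bond donor of sulfamoyl and has one heavy atom fewer. No measurement at hand bears on the reason for this result.

As far as these compounds go, whether an amine or a carboxylic acid at this position would give a similar number stays open. So does the effect of a longer chain in place of the 3-chloropropoxy group.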